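This account rests on a few compounds, and the source may have more. Where it says the series, first, only, none or still open, it means among the compounds named here.

Values so far in a functional assay (trachea) with Cavia porcellus as the target; a lower number here means that less compound is needed, a higher number that more compound is needed for the effect:
compound 1 `C=CCn1c(=O)c2[nH]cnc2n(CCC)c1=O` gives 1600 nM
compound 2 `CCCn1c(=O)n(CCC(=O)O)c(=O)c2[nH]cnc21` gives 21200 nM
compound 3 `CCCn1c(=O)n(CCC(N)=O)c(=O)c2[nH]cnc21` gives 13100 nM

Compound 3 holds the second highest of the three numbers. It lies within the scatter of compound 2 and well above compound 1.

Compound 4 `CCCn1c(=O)n(CCC#N)c(=O)c2[nH]cnc21` is not yet measured. Its difference from compound 3 is cyano in place of carbamoyl on a saturated chain carbon, two bonds along the chain from an aromatic nitrogen.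

Among the measured compounds shown here, no measured step makes this exact change, and no cyano compound has a value yet. The closest evidence is a 1.6-fold lower number from compound 2 to compound 3 (0.21 log units; within the scatter), where amino replaces hydroxy on a carbonyl carbon. The two replacements of vinyl give much larger moves, namely a 13-fold higher number from compound 1 to compound 2 (1.12 log units; beyond the scatter) and an 8.2-fold higher number from compound 1 to compound 3 (0.91 log units; beyond the scatter). Both chains ending in a carbonyl group therefore stand well above the vinyl compound. Compound 4 loses that carbonyl group, so a partial return towards compound 1 is the working expectation in this assay, though on thin evidence. A modest move to a lower number is expected, close to the edge of the scatter.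

The estimated change is a 2.2-fold lower number from compound 3 to compound 4 (0.34 log units; beyond the scatter) and could still fall within the scatter.

For compound 4 the estimate is 6000 nM with an expected range of 2000 nM to 16000 nM.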

Compound 4, half-maximal effective concentration: 1700 nM
For compound 4 the middle estimate is 3.5-fold (0.55 log units) above the measured one, and the stated range ends above it.
By their numbers in this assay, from the lowest: compounds 1 and 4 (each within the scatter of the next); then compounds 3 and 2 (each within the scatter of the next).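

Working notes on the chain end at this place, on a saturated chain carbon, two bonds along the chain from an aromatic nitrogen. In this assay, among the compounds shown here, the earlier compounds showed only that the carboxy and carbamoyl ends could not be separated from each other; the nitrile now shows that the end group itself moves the number strongly, with a 7.7-fold lower number from compound 3 to compound 4 (0.89 log units; beyond the scatter) and a 12-fold lower number from compound 2 to compound 4 (1.10 log units; beyond the scatter). The 2-cyanoethyl chain also stands level with the allyl chain of compound 1, with a 1.1-fold higher number from compound 1 to compound 4 (0.03 log units; within the scatter), so the high numbers of compound 2 and compound 3 do not follow from a substituted chain of this kind as such, only from those two carbonyl-bearing ends among the compounds shown. Nothing measured here explains why the nitrile differs from those two ends.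

The compounds shown do not separate the carbonyl from the amide hydrogen or the acid hydrogen as the feature that tracks with the higher numbers, which a methyl ester or a dimethylamide at the same place would address. Going by these compounds, it also remains open how far the level shared by compound 1 and compound 4 extends to other ends, such as an amine, a hydroxyl or the longer 3-cyanopropyl chain.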